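Working notes: side-chain amines, compound 3 to compound 4

The source may hold more compounds than are shown below. What is called first, only, known or untested is meant among the compounds shown, and "the series" means these compounds.

Measured in a functional assay on HeLa cells (Homo sapiens) for antiproliferative activity, read by CCK-8 assay, with a stated time of 48 h; a lower number here means a stronger inhibitor, a higher number a weaker inhibitor:
- compound 1 `COc1ccc(/C=C\c2cc(OC)c(OC)c(OC)c2)cc1OCc1ccc(C=O)cc1`: 4800 nM
- compound 2 `COc1ccc(/C=C\c2cc(OC)c(OC)c(OC)c2)cc1OCc1ccc(CNCCO)cc1`: 4400 nM
- compound 3 `COc1ccc(/C=C\c2cc(OC)c(OC)c(OC)c2)cc1OCc1ccc(CNCCN(C)C)cc1`: 9400 nM

Compound 3 stands close to compound 1, with a 2.0-fold higher number from compound 1 to compound 3 (0.29 log units; within the scatter). It stands slightly further from compound 2, with a 2.1-fold higher number from compound 2 to compound 3 (0.33 log units; beyond the scatter). Compound 4 `COc1ccc(/C=C\c2cc(OC)c(OC)c(OC)c2)cc1OCc1ccc(CNCCNC(C)=O)cc1` differs from compound 3 in one place: acetamido in place of dimethylamino on a saturated chain carbon, two bonds along the chain from an amine nitrogen. Among the measured compounds shown here, no measured compound carries acetamido, so no step speaks to it directly. The nearest guide is the change at this same place between compound 2 and compound 3, which is barely beyond the scatter. The other steps, including a 1.1-fold lower number from compound 1 to compound 2 (0.04 log units; within the scatter), stay within it. In this assay the expected step is a 1.4-fold lower number from compound 3 to compound 4 (0.16 log units; within the scatter), so no change beyond the scatter is expected. The estimate for compound 4 is 6500 nM, with an expected range of 3000 nM to 14000 nM.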

Compound 4, half-maximal inhibitory concentration: 6400 nM
Estimate against measurement, compound 4: 1.0-fold (0.01 log units) above, within the range that was stated.
By their numbers in this assay, from the lowest: compounds 2, 1, 4 and 3 (each within the scatter of the next, the first and the last beyond it).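

In this assay, acetamido at this saturated chain carbon stays within the scatter of dimethylamino a 1.5-fold lower number from compound 3 to compound 4 (0.17 log units; within the scatter) and of hydroxy a 1.5-fold higher number from compound 2 to compound 4 (0.16 log units; within the scatter), and the full ((2-acetamidoethyl)amino)methyl group stays within it of formyl a 1.3-fold higher number from compound 1 to compound 4 (0.12 log units; within the scatter). Hydroxy and dimethylamino remain the only pair at this place separated beyond the scatter, and acetamido sits within the scatter of both. No measured evidence accounts for these numbers.

Still open, from the compounds shown here alone, is whether a carboxylic acid, a morpholine or a longer chain at this place would give a step beyond the scatter.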